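The compounds below may be only part of what the source reports. "The series", "measured", "known", "first", "only" and "open" are said of these compounds alone.

Measured compounds:
compound 1 `CC(C)C(C(N)=O)c1ccc(Cl)cc1`, > 100000 nM
compound 2 `CC(C)[C@H](C(=O)Nc1ccccc1)c1ccc(Cl)cc1`, > 100000 nM
compound 3 `CC(C)[C@H](C(=O)Nc1nnc(C(F)(F)F)s1)c1ccc(Cl)cc1`, 1900 nM

In a functional assay on CHO cells for agonist activity at Free fatty acid receptor 2 (Homo sapiens), read by cAMP accumulation (on this read-out lower numbers stand for stronger inhibition and higher numbers for weaker inhibition), compound 1 reaches only a limit, > 100000 nM, and not a number. Compound 2 likewise stands at a limit in this assay, > 100000 nM, and so it cannot be placed on a scale against the other two; it shares this position with compound 1, as the limit of > 100000 nM in this assay, at which 2 of the 3 values shown sit, shows. Compound 3 alone gives a measured value in this assay, 1900 nM.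

Compound 4 `CC(C)[C@H](C(=O)NC1=NC(=O)CS1)c1ccc(Cl)cc1` has not yet been measured. It differs from compound 2 in one place: a group of 6 heavy atoms (3 carbon, 1 nitrogen, 1 oxygen, 1 sulfur; one five-membered non-aromatic ring with 2 hetero atoms) in place of a group of 6 heavy atoms (6 carbon; one six-membered aromatic ring of carbon only), on an amide-type nitrogen. Among the compounds with values here, no step between measured compounds is available to anchor this change. Still, compound 3 shows that a heterocycle on the amide-type nitrogen can give a measurable value where the phenyl of compound 2 gives none, so a step in this assay from a limit to a measurable number is expected for compound 4, though weaker than compound 3. In this assay compound 4 is expected to give 15000 nM, between 2000 nM and 100000 nM, which means an expected step of an at least 6.6-fold lower number from compound 2 to compound 4 (0.82 log units; beyond the scatter).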

Compound 4, half-maximal inhibitory concentration: 20000 nM
Compound 4: the middle estimate sits 1.3-fold (0.12 log units) below what was measured; the measured number falls inside the stated range.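

In this assay the change of phenyl for the five-membered non-aromatic ring on the amide-type nitrogen gives an at least 5.0-fold lower number from compound 2 to compound 4 (0.69 log units; beyond the scatter). A measured number on this nitrogen therefore no longer rests on compound 3 alone: compound 3 gives 1900 nM and compound 4 gives 20000 nM. Compound 2 remains a limit of the assay, > 100000 nM, so the true size of this step stays unknown, and the limit is a shared one: the limit of > 100000 nM in this assay, at which 2 of the 4 values shown sit.

From the compounds shown here alone, what the carbonyl and the sulfur of the new ring each contribute stays open. So does how a carboxylic acid, an amine or a longer alkyl chain on the amide-type nitrogen would read in this assay.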